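The compounds below may be only part of what the source reports. "The series", "measured", "known", "first", "only" and "open" are said of these compounds alone.

Measured so far:
- compound 1 `CCO/C(O)=C1\C(COCCNC2=NC(=O)C(C)(C)N2)=NC(C)=C(C(=O)OC)C1c1cccc(Cl)c1Cl`: in a functional assay (aorta) with Rattus norvegicus as the target (on this read-out higher numbers stand for weaker inhibition and lower numbers for stronger inhibition), compound 1 gives 20 nM
- compound 2 `CCO/C(O)=C1\C(COCCNc2nc(O)cc(-c3ccccc3)n2)=NC(C)=C(C(=O)OC)C1c1cccc(Cl)c1Cl`: in this assay compound 2 gives 7.94 nM

Compound 1 holds the higher of the two numbers; compound 2 sits lower, and that gap lies beyond the usual scatter. Compound 3 `CCO/C(O)=C1\C(COCCNc2n[s+]([O-])nc2N)=NC(C)=C(C(=O)OC)C1c1cccc(Cl)c1Cl` is not yet measured. Against compound 1 it carries a group of 7 heavy atoms (2 carbon, 3 nitrogen, 1 oxygen, 1 sulfur; one five-membered aromatic ring with 3 hetero atoms) in place of a group of 8 heavy atoms (5 carbon, 2 nitrogen, 1 oxygen; one five-membered non-aromatic ring with 2 hetero atoms), on an amine nitrogen. Among the measured compounds shown here, no measured pair covers this exchange, so its direction is open; a step within the scatter is expected, with no lean either way. For compound 3 the expected value in this assay is 20 nM, within 6 nM to 60 nM. The expected step is no change at the digits printed from compound 1 to compound 3 (within the scatter).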

Compound 3, half-maximal inhibitory concentration: 15.9 nM
Beside the measured number, compound 3's estimate is 1.3-fold (0.10 log units) above it; the measured number falls inside the stated range.
By their numbers in this assay, from the lowest: compounds 2, 3 and 1 (each within the scatter of the next, the first and the last beyond it).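

In this assay the exchange on the amine nitrogen gives a 1.3-fold lower number from compound 1 to compound 3 (0.10 log units; within the scatter) and so stays within the scatter. This position therefore accepts a five-membered aromatic ring with 3 hetero atoms, one of them sulfur, in place of a five-membered non-aromatic ring with 2 hetero atoms, with no readable change in the number. No supporting measurement bears on why the two groups read alike. Still open, as far as these compounds go, is whether this nitrogen needs a ring at all, or whether a simple acyl group or a plain methyl group would read the same. A longer chain between the ether oxygen and this nitrogen also remains untested in the compounds shown.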